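This account rests on a few compounds, and the source may have more. Where it says the series, first, only, none or still open, it means among the compounds named here.

Of the compounds shown here, two have been measured in a functional assay on SHEP cells (Homo sapiens) for antiproliferative activity, read by spectrophotometry and resazurin assay, with a stated time of 72 h; on this read-out lower numbers stand for stronger inhibition and higher numbers for weaker inhibition. Within the data shown here, compound 1 `Cc1ccc(C(=O)CC2Oc3cc(O)ccc3C=C2c2ccc(O)cc2)cc1` gives 60000 nM and compound 2 `COc1ccc(C(=O)CC2Oc3cc(O)ccc3C=C2c2ccc(O)cc2)cc1` gives 37000 nM; the one measured step, a 1.6-fold lower number from compound 1 to compound 2 (0.21 log units; within the scatter), stays within the scatter, so the two values are not distinguished. Compound 3 `O=C(CC1Oc2cc(O)ccc2C=C1c1ccc(O)cc1)c1cccc2ccccc12` carries naphthalen-1-yl in place of 4-methoxyphenyl on a carbonyl carbon. Among the measured compounds shown here, no measured step touches the group on the carbonyl carbon, and the single step available points in no direction, so no change beyond the scatter is expected in this assay. Compound 3 is therefore estimated at 30000 nM, range 10000 nM to 90000 nM. The step this estimate means is a 1.2-fold lower number from compound 2 to compound 3 (0.09 log units; within the scatter).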

Compound 3, half-maximal inhibitory concentration: 128000 nM
Estimate against measurement, compound 3: 4.3-fold (0.63 log units) below; the measured number lies above the stated range.
By their numbers in this assay, from the lowest: compounds 2 and 1 (each within the scatter of the next); then compound 3.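

In this assay, the group on the carbonyl carbon now shows a measurable effect: naphthalen-1-yl gives a 3.5-fold higher number from compound 2 to compound 3 (0.54 log units; beyond the scatter), and likewise a 2.1-fold higher number from compound 1 to compound 3 (0.33 log units; beyond the scatter). Both steps are modest but beyond the scatter, unlike the exchange of methyl for methoxy, so this position responds to a change of the aryl group itself. No measured evidence bears on the reason for this.

Still open, as far as these compounds go, is whether another group on the carbonyl carbon, such as an amine or a carboxylic acid, would give a lower number than compound 2.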